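Furan in place of methoxyphenyl: lipophilicity of a new analogue

The compounds below may be only part of what the source reports. "The series", "measured", "known", "first", "only" and "open" are said of these compounds alone.

Measured so far:
- compound 1, `COc1ccc(C2C(C(=O)OCc3ccccn3)=C(C)NC3=C2C(=O)CCC3)cc1`: 1.9
- compound 2, `CC1=C(C(=O)OCc2cccnc2)C(c2ccccc2[N+](=O)[O-])C2=C(CCCC2=O)N1`: 1.51

In a physicochemical assay for lipophilicity, measured as octanol-water partition (a higher number here means a more lipophilic compound, a lower number a more polar compound), compound 1 gives 1.9 and stands highest of the two numbers; compound 2, the nearest, gives 1.51, a gap that lies beyond the scatter. Going by the values given here, no step between two measured compounds that differ in one place is available, so the size of a single substituent swap is not yet calibrated.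

Compound 3, `CC1=C(C(=O)OCc2ccccn2)C(c2ccco2)C2=C(CCCC2=O)N1`, is the next candidate for this assay. It differs from compound 1 as follows: furan-2-yl in place of 4-methoxyphenyl on a saturated ring carbon. A six-membered aromatic ring of carbon only with its methoxy group leaves, and a smaller five-membered aromatic ring with one hetero atom enters on the saturated ring carbon of the shared core.

Going from compound 1 to compound 3, the partition coefficient is expected to fall by a clear step, beyond the scatter, given that compound 1 sits at 1.9 and the change removes three heavy atoms of the aromatic part. The estimated step is a number 0.60 log units lower from compound 1 to compound 3 (beyond the scatter). Compound 3 is therefore estimated at 1.3, with a range of 0.9 to 1.7.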

Compound 3, partition coefficient: 1.4
Estimate against measurement, compound 3: 0.10 log units below; the measured number falls inside the stated range.
By their numbers in this assay, from the lowest: compounds 3 and 2 (each within the scatter of the next); then compound 1.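

Going by these compounds alone, the exchange of 4-methoxyphenyl for furan-2-yl on the saturated ring carbon gives the first single-place step: in this assay it amounts to a number 0.50 log units lower from compound 1 to compound 3 (beyond the scatter). The group on this carbon therefore registers in this read-out, since 8 heavy atoms leave, 5 enter, and the ((pyridin-2-yl)methoxy)carbonyl group and the shared core stay the same. No supporting measurement bears on why the number moves.

Within the data shown here, the single step changes the ring and removes the methoxy group together, so the share of each remains open; an unsubstituted phenyl or a thiophen-2-yl group on the same carbon would help separate them. Also open, on these data alone, is how an amine, a carboxylic acid or a longer chain on this carbon would read in this assay, and whether the same exchange gives a step of similar size with a different ester group on the core.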